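The source may report more compounds than this note shows. Statements on the series, on what has been measured and on what is new or still open speak of the compounds shown alone.

Compound 1, `CC(C)C(c1ncc[nH]1)c1ccc(-c2ccc3cccc(F)c3c2)[nH]c1=O`, gives in an ADME assay on microsomes from liver (Mus musculus) for metabolic stability (a higher number here means that the compound lasts longer, a lower number that the compound disappears faster), the value < 0.0667 h, which is a limit of the assay and not a number.
Compound 2, `CC(C)C(Cc1ncc[nH]1)c1ccc(-c2ccc3cccc(F)c3c2)[nH]c1=O`, gives in this assay the value < 0.0667 h, again a limit and not a number.
Compound 3, `CC(C)C(Cc1nnn[nH]1)c1ccc(-c2ccc3cccc(F)c3c2)[nH]c1=O`, gives in this assay the value 0.853 h.

Compound 1 therefore sits at the lowest edge that this assay can report, and the wider picture is the limit of < 0.0667 h in this assay, at which 2 of the 3 values shown sit. Compound 4, `CC(C)C(CC(N)=O)c1ccc(-c2ccc3cccc(F)c3c2)[nH]c1=O`, differs from compound 1 by carbamoylmethyl in place of 1H-imidazol-2-yl on a saturated chain carbon bound to an aromatic carbon and a saturated chain carbon. Going by the values given here, no measured step makes exactly this change. The step that comes closest is an at least 12-fold higher number from compound 1 to compound 3 (1.10 log units; beyond the scatter), where the same imidazole ring leaves and a tetrazolylmethyl group enters; the other step, a step that the two limits leave unreadable from compound 1 to compound 2, only moves the ring one bond outward. An upward move in this assay is expected for compound 4, although a smaller one than for compound 3, since the group that enters is not the one measured. Compound 4 is expected to give about 0.3 h, in a range from 0.07 h to 1.2 h. The estimate corresponds to an expected step of an at least 4.4-fold higher number from compound 1 to compound 4 (0.65 log units; beyond the scatter).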

Compound 4, half-life: < 0.0667 h
Compound 4 gave a limit, no number; the forecaster's own chance of this, stated with the estimate: 30%; middle value at least 4.4-fold (0.65 log units) away from the limit.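

Putting carbamoyl in place of 1H-tetrazol-5-yl, two bonds along the chain from an aromatic carbon, gives in this assay an at least 12-fold lower number from compound 3 to compound 4 (1.10 log units; beyond the scatter). Going by these compounds alone, the longer survival of compound 3 therefore does not come with every group that replaces the imidazole ring at this place: compound 4, with its carbamoylmethyl group and no ring, also ends at a limit of the assay, leaving compound 3 as the only compound here with a readable number. Limits now dominate the set: the limit of < 0.0667 h in this assay, at which 3 of the 4 values shown sit.

On these data alone, the steps from compound 1 and from compound 2 to compound 4 cannot be read, so how these three compounds rank remains unknown. As far as these compounds go, whether a carboxylic acid or an amine on the same chain would behave like the tetrazole of compound 3 or like the carbamoyl group of compound 4 also stays open.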